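Lengthening the chain: from compound 3 to compound 4

The source may report more compounds than this note shows. Statements on the series, on what has been measured and on what is new or still open speak of the compounds shown alone.

In a functional assay on A549 cells (Homo sapiens) for inhibition, with a stated time of 48 h, tested at 50 uM (a higher number here means more inhibition of growth at the concentration tested, a lower number less inhibition of growth), compound 1 (`C=C[C@@](C)(/C=C/c1ccc(OC(=O)CCC)cc1)CCC=C(C)C`) reads 50% and compound 2 (`C=C[C@@](C)(/C=C/c1ccc(OC(=O)CCCC)cc1)CCC=C(C)C`) reads 38% while compound 3 (`C=C[C@@](C)(/C=C/c1ccc(OC(=O)CCCCCCC)cc1)CCC=C(C)C`) reads 15% as the lowest of the three, beyond the scatter from both others.

Compound 4 (`C=C[C@@](C)(/C=C/c1ccc(OC(=O)CCCCCCCCCCCCCCC)cc1)CCC=C(C)C`) keeps the shared core and extends the same saturated chain. The whole change is octyl in place of hydrogen on a saturated chain carbon, seven bonds along the chain from a carbonyl carbon and nothing else differs.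

Among the measured compounds shown here, three measured steps bear on this change, each of them a lengthening of that chain. The shortest extension gives a number 12 percentage points lower from compound 1 to compound 2 (beyond the scatter) and the next gives a number 23 percentage points lower from compound 2 to compound 3 (beyond the scatter) while the full span gives a number 35 percentage points lower from compound 1 to compound 3 (beyond the scatter) as the largest of the three. All point the same way, and none of the three compounds goes against the trend.

The extension in compound 4 is longer than any of these, which points to a further fall in this assay as well. However, compound 3 at 15% leaves little room at the low end of the read-out, so a drop as large as the earlier ones is not expected.

The expected step is a number 9 percentage points lower from compound 3 to compound 4 (within the scatter) and its direction is downward. For compound 4 the estimated value is 6% with an expected range from 0% to 17% in this series.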

Compound 4, percent growth inhibition at one concentration: 61%
Compound 4: the middle estimate sits 55 percentage points below what was measured; measured number outside the range, above it.
By their numbers in this assay, from the lowest: compound 3; then compound 2; then compound 1; then compound 4.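

In this assay, among the compounds shown here, the octyl extension, seven bonds along the chain from a carbonyl carbon, gives a number 46 percentage points higher from compound 3 to compound 4 (beyond the scatter) and so reverses the direction of the earlier steps: lengthening this chain does not move the read-out one way across the whole series. The fall in growth inhibition holds only through compounds 1, 2 and 3, and compound 4 goes against it, with a number 23 percentage points higher from compound 2 to compound 4 (beyond the scatter) and a number 11 percentage points higher from compound 1 to compound 4 (beyond the scatter) placing it highest of the four. The data at hand offer no measurement that explains the turn in direction.

Where the turn lies remains open: butyl or hexyl in place of hydrogen at this same place, seven bonds along the chain from a carbonyl carbon, would show whether the read-out climbs gradually from the low point of compound 3 or jumps only at the full octyl length. A longer chain than that of compound 4 would show whether the rise continues, levels off or falls again.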